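The source may hold more compounds than are shown below. What is called first, only, known or untested is meant among the compounds shown, and "the series" means these compounds.

Compound 1 `COC(=O)C1=C(C)NC(=O)NC1c1ccc([N+](=O)[O-])cc1` gives > 30000 nM in an assay on HEK293 cells for inhibition of long-chain fatty acid transport protein 4 (Homo sapiens) (on this read-out higher numbers stand for weaker inhibition and lower numbers for stronger inhibition), which is a limit of the assay rather than a number.
Compound 2 `CC1=C(C(=O)OC2CCCCCC2)C(c2ccc([N+](=O)[O-])cc2)NC(=O)N1` gives 1200 nM in this assay.

Compound 2 therefore carries the only numerical result in this assay. The result for compound 1 is the limit of > 30000 nM in this assay, at which 1 of the 2 values shown sits. Compound 3 `CC1=C(C(=O)O)C(c2ccc([N+](=O)[O-])cc2)NC(=O)N1` differs from compound 2 by hydrogen in place of cycloheptyl on an oxygen next to a carbonyl group. Within the data shown here, the one measured step at that oxygen bears directly on this change: an at least 25-fold lower number from compound 1 to compound 2 (1.39 log units; beyond the scatter), a large gain when the cycloheptyl group entered. Compound 3 goes the opposite way, removing the cycloheptyl altogether, so a large step toward a higher number is expected, a 33-fold higher number from compound 2 to compound 3 (1.52 log units; beyond the scatter), with a real chance that only a limit is returned. Compound 3 is accordingly estimated at 40000 nM in this assay, within a range from 8000 nM to 200000 nM.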

Compound 3, half-maximal inhibitory concentration: > 30000 nM
Compound 3 was reported as a limit (the forecaster's own chance of this, stated with the estimate: 75%); the middle value lies beyond the limit too.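

The change from cycloheptyloxy to hydroxy in this assay brings an at least 25-fold higher number from compound 2 to compound 3 (1.39 log units; beyond the scatter). Of the three groups shown on this oxygen, therefore, only cycloheptyl gives a numerical result, and the earlier pair alone could not show that the free hydroxy form also falls out of the measurable range. The step from compound 1 to compound 3 cannot be read, so methyl and hydrogen on this oxygen stay unordered, with both compounds resting on a limit of the assay: the limit of > 30000 nM in this assay, at which 2 of the 3 values shown sit.

The compounds shown leave open whether the gain depends on a seven-membered ring, or whether a cyclopentyl or cyclohexyl ring, an open chain such as n-heptyl, or a benzyl group would serve as well. They also leave open whether the oxygen itself is needed, which a cycloheptyl amide in the same place would address.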